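The source may report more compounds than this note shows. Statements on the series, on what has been measured and on what is new or still open speak of the compounds shown alone.

Working notes on the benzamido series.

Compound 1 `COc1cc2oc(-c3cccc(NC(=O)c4ccccc4)c3)cc(=O)c2c(OC)c1OC` gives 12100 nM in a functional assay on MCF7 cells (Homo sapiens) for inhibition, read by MTT assay; on this read-out lower numbers stand for stronger inhibition of growth and higher numbers for weaker inhibition of growth. Within the data shown here, it holds the lowest of the three numbers so far, but its nearest companion, compound 3 `COc1cc2oc(-c3cccc(NC(=O)c4ccc(C#N)cc4)c3)cc(=O)c2c(OC)c1OC` at 12700 nM, lies at a 1.0-fold higher number from compound 1 to compound 3 (0.02 log units; within the scatter), and the furthest, compound 2 `COc1cc2oc(-c3cccc(NC(=O)c4ccc([N+](=O)[O-])cc4)c3)cc(=O)c2c(OC)c1OC` at 20100 nM, lies at a 1.7-fold higher number from compound 1 to compound 2 (0.22 log units; within the scatter); the remaining pair shows a 1.6-fold lower number from compound 2 to compound 3 (0.20 log units; within the scatter). All three steps stay within the scatter, so the three compounds are not separated by this assay.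

Compound 4 `COc1cccc(C(=O)Nc2cccc(-c3cc(=O)c4c(OC)c(OC)c(OC)cc4o3)c2)c1` differs from compound 1 as follows: methoxy in place of hydrogen on an aromatic carbon. Among the measured compounds shown here, no measured step places a methoxy anywhere, so the closest guidance is indirect: the two substituents already tried on an aromatic carbon of the benzamido group, nitro and cyano, each moved this assay by no more than the scatter. The same is therefore expected for compound 4, a step in neither direction beyond the scatter.

Compound 4 is expected at 12000 nM, with a range of 5000 nM to 30000 nM. Relative to compound 1, the expected step is a 1.0-fold lower number from compound 1 to compound 4 (0.00 log units; within the scatter).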

Compound 4, concentration for 50% growth inhibition: 7670 nM
For compound 4 the middle estimate is 1.6-fold (0.19 log units) above the measured one; low and high end bracket the measured number.
By their numbers in this assay, from the lowest: compounds 4, 1, 3 and 2 (each within the scatter of the next, the first and the last beyond it).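

Among these compounds, the 3-methoxyphenyl group gives the only step that clears the scatter in this assay (a 2.6-fold lower number from compound 2 to compound 4 (0.42 log units; beyond the scatter)), and that separation is modest. Set against the unsubstituted group (a 1.6-fold lower number from compound 1 to compound 4 (0.20 log units; within the scatter)) and the 4-cyanophenyl group (a 1.7-fold lower number from compound 3 to compound 4 (0.22 log units; within the scatter)), it stays within the scatter, so methoxy in place of hydrogen on this ring is not separated from hydrogen, and the 3-methoxyphenyl group stands apart from the 4-nitrophenyl group alone. That one step changes both the group and its place on the ring, and no supporting data bear on the result.

From the compounds shown here alone, whether the step follows the methoxy group or its place on the ring stays open. An amine, a carboxylic acid or a longer alkoxy chain on this ring would show whether any group moves this read-out clearly from the hydrogen of compound 1.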